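The source may report more compounds than this note shows. Statements on the series, on what has been measured and on what is new or still open speak of the compounds shown alone.

Three compounds from one series share a core in which a carboxylic acid on a pyridine is joined through a methylene to a fused bicyclic ring system that carries an aryl substituent. Compound 1 `O=C(O)c1cccc(Cc2c(-c3ccccc3)nn3ccccc23)n1` gives 2300 nM in a functional assay on cells for antagonist activity at prostaglandin E2 receptor EP1 subtype (Rattus norvegicus), read by fluorescence and calcium flux, with a stated time of 60 s; on this read-out lower numbers stand for stronger inhibition and higher numbers for weaker inhibition. Compound 2 `O=C(O)c1cccc(Cc2c(-c3ccccc3)nn3cc(C4CC4)ccc23)n1` differs from it by a single group, and in this assay compound 2 gives 190 nM; that change is a 12-fold lower number from compound 1 to compound 2 (1.08 log units; beyond the scatter). Compound 3 `COc1ccc(-c2nn3cc(Cl)ccc3c2Cc2cccc(C(=O)O)n2)cc1` carries a chlorine on the six-membered ring together with a methoxy group on the pendant aryl, and in this assay compound 3 gives 5400 nM, the highest number of the three, so it is the weakest inhibitor shown here.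

Compound 4 `O=C(O)c1cccc(Cc2c(-c3ccco3)nn3cc(Cl)ccc23)n1` is reached from compound 3 by one change: furan-2-yl in place of 4-methoxyphenyl on an aromatic carbon. Going by the values given here, no measured step touches this position; the only measured step concerns a different part of the molecule and cannot guide the expectation for the pendant aryl. The values of compounds 1 and 3 show that a methoxyphenyl with a chlorine sits above an unsubstituted phenyl, but those two differ in two places at once. Among the compounds with values here, with no direct precedent, the step of a 3.6-fold lower number from compound 3 to compound 4 (0.56 log units; beyond the scatter) is estimated to be modest, and compound 4 is expected to give about 1500 nM, within a broad range from 300 nM to 8000 nM.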

Compound 4, half-maximal inhibitory concentration: 1200 nM
For compound 4 the middle estimate is 1.3-fold (0.10 log units) above the measured one; the range from low to high includes it.
By their numbers in this assay, from the lowest: compound 2; then compounds 4 and 1 (each within the scatter of the next); then compound 3.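

Going by these compounds alone, replacing 4-methoxyphenyl with furan-2-yl gives a 4.5-fold lower number from compound 3 to compound 4 (0.65 log units; beyond the scatter) in this assay and is the first measured change to this group, which shows that the read-out responds to what sits on this aromatic carbon of the five-membered ring. With the chlorine of compound 3 kept in place, the six-membered carbon ring can give way to a five-membered aromatic ring with fewer heavy atoms, and inhibition becomes stronger rather than weaker. Nothing measured here explains why this swap strengthens inhibition.

The swap removes the methoxy group and changes the ring in a single step, so the compounds shown leave open how much of the gain belongs to each of these two differences. Also open, as far as these compounds go, are how a thiophene or pyridine ring would compare on this carbon, and whether furan-2-yl would give a similar step when the cyclopropyl group of compound 2 stands in place of the chlorine.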